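Turning the single stereocentre of a TET2 inhibitor

A few compounds are considered here, and "the series" means these few. Any claim that something is new, unique, unknown or untested is made for them only; others in the source may bear on it.

For the measured compounds named here, compound 2 `C=C(C[C@H](O)C(=O)O)C(=O)O` is a small hydroxy diacid with one stereocentre drawn as S. In an assay for inhibition of methylcytosine dioxygenase TET2 (Homo sapiens), read by ELISA, with a stated time of 2 h (on this read-out higher numbers stand for weaker inhibition and lower numbers for stronger inhibition), compound 2 gives 10500 nM, the second highest of the three numbers so far. Its closest neighbour is compound 1 `C=C(CC(O)C(=O)O)C(=O)O`, which gives 9400 nM; the step of a 1.1-fold higher number from compound 1 to compound 2 (0.05 log units; within the scatter) is small. The furthest is compound 3 `C=C(CC(O)(C(=O)O)C(F)(F)F)C(=O)O`, which gives 108000 nM after the step of an 11-fold higher number from compound 1 to compound 3 (1.06 log units; beyond the scatter). Compound 4 `C=C(C[C@@H](O)C(=O)O)C(=O)O` differs from compound 2 only in configuration: the two compounds have the same atoms and bonds and differ only in configuration as drawn: 1 of 1 stereo elements differ; a stereocentre at a saturated chain carbon is drawn S in compound 2 and R in compound 4. The step that bears on this is a 1.1-fold higher number from compound 1 to compound 2 (0.05 log units; within the scatter), since the fact that one of compounds 1 and 2 is drawn with a defined configuration and the other without, at the place where they differ makes compound 1 the undefined form. As that step stayed within the scatter, compound 4 is expected to change by about a 1.1-fold higher number from compound 2 to compound 4 (0.06 log units; within the scatter), with an estimated 12000 nM (range 5000 nM to 40000 nM).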

Compound 4, half-maximal inhibitory concentration: 11000 nM
For compound 4 the middle estimate is 1.1-fold (0.04 log units) above the measured one; measured number inside the range.
By their numbers in this assay, from the lowest: compounds 1, 2 and 4 (each within the scatter of the next); then compound 3.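

In this assay, the S and R forms at this stereocentre can now be compared directly, and the step is a 1.0-fold higher number from compound 2 to compound 4 (0.02 log units; within the scatter). The form drawn without a configuration also sits close to the R form, with a 1.2-fold higher number from compound 1 to compound 4 (0.07 log units; within the scatter). Turning this saturated chain carbon therefore leaves the number within the scatter, a reading that rests on a single pair: the fact that compounds 2 and 4 differ only in the configuration as drawn.

Going by these compounds, it remains open whether configuration would matter equally little with an amine in place of the hydroxy group. On these data alone, the S and R forms of the trifluoromethyl compound 3 also remain open.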